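A Methoxy Group on the Weaker Phenyl Compound

This account rests on a few compounds, and the source may have more. Where it says the series, first, only, none or still open, it means among the compounds named here.

Within the data shown here, in a functional assay on LN-229 cells (Homo sapiens) for antiproliferative activity, with a stated time of 72 h (on this read-out lower numbers stand for stronger inhibition and higher numbers for weaker inhibition), compound 1 (`Nc1ncnn2c([C@@H]3O[C@H](CO)[C@@H](O)[C@H]3O)cc(C#CC3CC3)c12`) gives 30 nM and compound 2 (`Nc1ncnn2c([C@@H]3O[C@H](CO)[C@@H](O)[C@H]3O)cc(-c3ccccc3)c12`) gives 75100 nM as the higher of the two numbers so far. Compound 3 (`COc1ccc(-c2cc([C@@H]3O[C@H](CO)[C@@H](O)[C@H]3O)n3ncnc(N)c23)cc1`) keeps the shared core and alters only the phenyl of compound 2 (methoxy in place of hydrogen on an aromatic carbon): it has methoxy in place of hydrogen on an aromatic carbon, para to a large group, so that phenyl becomes 4-methoxyphenyl.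

Among the measured compounds shown here, the one measured step, a 2500-fold higher number from compound 1 to compound 2 (3.40 log units; beyond the scatter) with phenyl in place of 2-cyclopropylethynyl on an aromatic carbon, is large. That step exchanged the whole group, however, whereas compound 3 keeps the phenyl and adds to it. For the measured compounds named here, it therefore bears only indirectly, and no measured step shows what a methoxy does here. A change of that size is not expected in this assay for this smaller edit. The expected change is small, an estimated 1.3-fold lower number from compound 2 to compound 3 (0.10 log units; within the scatter) with no firm direction. For compound 3 the expected value is an estimated 60000 nM with a likely range from 15000 nM to 150000 nM in repeated measurements.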

Compound 3, half-maximal inhibitory concentration: 40300 nM
Beside the measured number, compound 3's estimate is 1.5-fold (0.17 log units) above it; low and high end bracket the measured number.
By their numbers in this assay, from the lowest: compound 1; then compounds 3 and 2 (each within the scatter of the next).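

In this assay, the first methoxy edit on this phenyl gives a 1.9-fold lower number from compound 2 to compound 3 (0.27 log units; within the scatter) and so does not separate the two compounds on this read-out. Adding methoxy para to a large group thus leaves compound 3 on the same footing as compound 2, and the wide gap to the alkyne compound remains, with a 1300-fold higher number from compound 1 to compound 3 (3.13 log units; beyond the scatter) as large a step in kind as a 2500-fold higher number from compound 1 to compound 2 (3.40 log units; beyond the scatter) and so not confined to the unsubstituted phenyl, though only these two aryl groups have been compared with the 2-cyclopropylethynyl group. Nothing available on these compounds accounts for either the small step or the large one.

As far as these compounds go, it remains open whether an amine, a hydroxyl or a fluorine in place of the methoxy on this ring would give a step beyond the scatter, or whether any substituted phenyl can come close to compound 1. Equally open, from the compounds shown here alone, is how much of the value of compound 1 would survive if its 2-cyclopropylethynyl group gave way to a plain ethynyl or to a longer alkyne chain.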